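A fluorine change at the assay limit

A few compounds are considered here, and "the series" means these few. Any claim that something is new, unique, unknown or untested is made for them only; others in the source may bear on it.

Measured in a functional assay on Jurkat cells (Homo sapiens); a lower number here means a stronger inhibitor, a higher number a weaker inhibitor:
- compound 1 `CC(C)[C@H](NC(=O)COc1cccc2ccccc12)C(=O)N[C@@H](CC(=O)O)C(=O)COc1ccc(OC(F)(F)F)cc1`: 29100 nM
- compound 2 `CC(C)[C@H](NC(=O)COc1cccc2ccccc12)C(=O)N[C@@H](CC(=O)O)C(=O)COc1ccccc1F`: > 100000 nM
- compound 3 `CC(C)[C@H](NC(=O)COc1cccc2ccccc12)C(=O)N[C@@H](CC(=O)O)C(=O)COc1cc(F)ccc1F`: > 100000 nM

Only compound 1, at 29100 nM, has a true number. Compound 2 gives > 100000 nM, which is a limit of the assay and not a number. Compound 3 gives > 100000 nM, which is also only a limit, and it stands at the limit of > 100000 nM in this assay, at which 2 of the 3 values shown sit.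

Compound 4 `CC(C)[C@H](NC(=O)COc1cccc2ccccc12)C(=O)N[C@@H](CC(=O)O)C(=O)COc1c(F)cc(F)cc1F` has 2,4,6-trifluorophenyl in place of 2,5-difluorophenyl on an oxygen on a saturated carbon.

The step between the two fluorinated neighbours, a step that the two limits leave unreadable from compound 2 to compound 3, cannot be sized. The steps away from compound 1 can be sized only in part: an at least 3.4-fold higher number from compound 1 to compound 2 (0.53 log units; beyond the scatter) and an at least 3.4-fold higher number from compound 1 to compound 3 (0.53 log units; beyond the scatter). With these steps as the guide, no step beyond the scatter is expected in this assay, and another limit is quite likely. The expected change is a number no higher from compound 3 to compound 4 (the limit leaves the size open). For compound 4 the estimate is 100000 nM, with an expected range of 40000 nM to 250000 nM.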

Compound 4, half-maximal inhibitory concentration: 6840 nM
Estimate against measurement, compound 4: 15-fold (1.16 log units) above; the measured number lies below the stated range.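

In this assay, a fluorinated ring on this oxygen can give a real number after all: the 2,4,6-trifluorophenyl group brings an at least 14-fold lower number from compound 3 to compound 4 (1.16 log units; beyond the scatter) and an at least 14-fold lower number from compound 2 to compound 4 (1.16 log units; beyond the scatter). The same group also outdoes the 4-(trifluoromethoxy)phenyl group, with a 4.3-fold lower number from compound 1 to compound 4 (0.63 log units; beyond the scatter), so what matters at this position is which fluorinated ring is attached, not simply whether fluorine is present. Compound 2 and compound 3 remain limits and not numbers, so the step between them still cannot be read and the two large steps give only a lower bound: the limit of > 100000 nM in this assay, at which 2 of the 4 values shown sit.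

Going by these compounds, it remains open whether the gain needs all three fluorines of the 2,4,6-trifluorophenyl group. Also open, on these data alone, is whether chlorine or a methoxy group in their place on the same ring would serve as well.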